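Amide variation on a shared core: thiazolyl in place of cyclopropyl

A few compounds are considered here, and "the series" means these few. Any claim that something is new, unique, unknown or untested is made for them only; others in the source may bear on it.

Maximal responses in a functional assay on HEK293 cells for positive allosteric modulation of metabotropic glutamate receptor 5 (Homo sapiens), read by calcium flux; on this read-out lower numbers stand for smaller maximal responses and higher numbers for larger maximal responses:

compound 1 `CC(C)C(=O)N1CCCn2nc(COc3ccccc3)cc21`: 59%
compound 2 `O=C(C1CC1)N1CCCn2nc(COc3ccccc3)cc21`: 61%
compound 3 `O=C(c1ccccc1)N1CCCn2nc(COc3ccccc3)cc21`: 63%

The three measured compounds share a core and differ only in the group on the carbonyl carbon. Compound 2 carries the cyclopropyl there; its nearest neighbour on the numbers is reached by the step of a number 2 percentage points higher from compound 1 to compound 2 (within the scatter), its furthest by the step of a number 2 percentage points higher from compound 2 to compound 3 (within the scatter), so all three values sit within the scatter of one another.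

Compound 4 `O=C(c1nccs1)N1CCCn2nc(COc3ccccc3)cc21` is not yet measured. Its change against compound 2 is 1,3-thiazol-2-yl in place of cyclopropyl on a carbonyl carbon.

Among the compounds with values here, the steps that bear on this change are those that exchange the group on the carbonyl carbon: a number 2 percentage points higher from compound 1 to compound 2 (within the scatter), a number 4 percentage points higher from compound 1 to compound 3 (within the scatter) and a number 2 percentage points higher from compound 2 to compound 3 (within the scatter). None of them leaves the scatter, whether the group is a small ring, a branched chain or an aromatic ring. Within the data shown here, no measured step covers a heteroaromatic ring, so the thiazolyl case is untested; no further ground for a step in either direction is available.

Accordingly the expected step is no change at the digits printed from compound 2 to compound 4 (within the scatter), none beyond the scatter. Compound 4 is estimated at 61% in this assay, within a range from 50% to 72%.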

Compound 4, largest response reached (reported as percent of maximum), in percent of the reference or control that the assay uses: 24%
Beside the measured number, compound 4's estimate is 37 percentage points above it, and the stated range ends above it.
By their numbers in this assay, from the lowest: compound 4; then compounds 1, 2 and 3 (each within the scatter of the next).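

The group on the carbonyl carbon, so far without a step beyond the scatter among isopropyl, cyclopropyl and phenyl, turns out to matter in this assay with a number 37 percentage points lower from compound 2 to compound 4 (beyond the scatter) and a number 39 percentage points lower from compound 3 to compound 4 (beyond the scatter) and also a number 35 percentage points lower from compound 1 to compound 4 (beyond the scatter) as the steps to 1,3-thiazol-2-yl. The position thus accepts a branched chain, a small ring and a phenyl ring with no step beyond the scatter, yet an aromatic ring as such does not keep the maximal response, as the step from phenyl to 1,3-thiazol-2-yl shows. Nothing available here accounts for this drop.

Open, going by these compounds, is whether the ring nitrogen, the ring sulfur or both go with the lower response. A thiophen-2-yl or pyridin-2-yl group on the same carbonyl carbon would show whether compound 4 stands alone or marks a wider trend among heteroaromatic rings.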